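A few compounds are considered here, and "the series" means these few. Any claim that something is new, unique, unknown or untested is made for them only; others in the source may bear on it.

Working notes on the series. For the measured compounds named here, compound 1 `O=C(O)Cc1sc(COc2ccc(Cl)cc2)nc1-c1ccc(Cl)cc1` is the one member with a number in an in vitro functional assay on HEK285-7 cells for antagonist activity at prostaglandin D2 receptor 2 (Homo sapiens), read by BRET and beta-arrestin recruitment; on this read-out lower numbers stand for stronger inhibition and higher numbers for weaker inhibition: compound 1 gives 370 nM. Compound 2 `CCC(c1ccccc1)c1nc(-c2ccc(Cl)cc2)c(CC(=O)O)s1` reaches only the limit of this assay, compound 2 giving > 100000 nM. Compound 3 `O=C(O)Cc1sc(C(c2ccc(F)cc2)c2ccc(F)cc2)nc1-c1ccnc(N2CCC2)c1` likewise stops at the limit in this assay, where compound 3 gives > 100000 nM. Compound 3 therefore stands at the limit of > 100000 nM in this assay, at which 2 of the 3 values shown sit, alongside compound 2, and nothing separates the two on the numbers shown. Compound 4 `COc1cc(-c2nc(C(c3ccc(F)cc3)c3ccc(F)cc3)sc2CC(=O)O)ccn1` keeps the rest of compound 3 and differs from it only in methoxy in place of azetidin-1-yl on an aromatic carbon, that is, 2-(azetidin-1-yl)pyridin-4-yl becoming 2-methoxypyridin-4-yl. Going by the values given here, no measured pair isolates this change, so its size is unknown; the only compound with a number, compound 1, differs from compound 2 and from compound 3 in several places at once and says nothing about this ring substituent. The step of an at least 1.6-fold lower number from compound 3 to compound 4 (0.22 log units; that floor lies within the scatter) is expected to be modest at most, with compound 4 most likely also arriving at the limit. Compound 4 is estimated at 60000 nM, within a range from 5000 nM to 100000 nM.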

Compound 4, half-maximal inhibitory concentration: 380 nM
Beside the measured number, compound 4's estimate is 160-fold (2.20 log units) above it, and the stated range ends above it.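

Methoxy in place of azetidin-1-yl on the aromatic carbon next to the ring nitrogen gives an at least 260-fold lower number from compound 3 to compound 4 (2.42 log units; beyond the scatter) in this assay, the only single-place change shown so far with a readable size. This step is a floor, not a full measure, since one end of it is a limit, and the true gap may be wider still. With the rest of the structure held, this one group separates a compound with a number from a compound at the limit: the limit of > 100000 nM in this assay, at which 2 of the 4 values shown sit.

On these data alone, whether an unsubstituted ring carbon, a dimethylamino group or a longer ethoxy chain at this position would stay close to compound 4 or fall back to the limit remains open. Also open, as far as these compounds go, is whether the same exchange would act alike with a different group in place of the two 4-fluorophenyl rings.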